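The source may report more compounds than this note shows. Statements on the series, on what has been measured and on what is new or still open speak of the compounds shown alone.

Measured compounds in the series:

Compound 1 `CNNc1nnc(-c2ccccc2C)s1` — in a functional assay on the whole organism with Mus musculus as the target, with a stated time of 1 h (a lower number here means that less compound is needed, a higher number that more compound is needed for the effect), compound 1 gives only the limit > 100 mg/kg.
Compound 2 `Cc1ccccc1-c1nnc(NNC2CCCC2)s1` — in this assay compound 2 gives only the limit > 100 mg/kg.
Compound 3 `Cc1ccccc1-c1nnc(NN(C)C)s1` — in this assay compound 3 gives only the limit > 100 mg/kg.

Compound 3 stands at a limit, not at a number, and the two other values shown sit at the same limit, as summed up in the limit of > 100 mg/kg in this assay, at which 3 of the 3 values shown sit. The steps on the shared core are therefore unreadable: a step that the two limits leave unreadable from compound 1 to compound 2, a step that the two limits leave unreadable from compound 1 to compound 3 and a step that the two limits leave unreadable from compound 2 to compound 3 each run between two limits and show no size.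

Compound 4 `Cc1ccccc1-c1nnc(NN(C)C(C)C)s1` differs from compound 3 by isopropyl in place of methyl on an amine nitrogen. Going by the values given here, the steps that bear on it, a step that the two limits leave unreadable from compound 1 to compound 3 and a step that the two limits leave unreadable from compound 2 to compound 3, alter the same amine nitrogen or its substituent and give no readable size, so nothing measured points to a change in this assay beyond the scatter in either direction. The expectation is that compound 4 again reaches only the limit, with the step that the limit leaves unreadable from compound 3 to compound 4 estimated as none beyond the scatter. Compound 4 is thus estimated at 150 mg/kg, within 60 mg/kg to 400 mg/kg, most likely reported as a limit.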

Compound 4, dose for half-maximal effect: > 100 mg/kg
Compound 4 gave a limit, no number (the forecaster's own chance of this, stated with the estimate: 80%); the middle value does not contradict the limit.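

Going by these compounds alone, the steps to compound 4 from compound 1, compound 2 and compound 3 in this assay cannot be read, and no new step follows, since all four compounds give only a limit: the limit of > 100 mg/kg in this assay, at which 4 of the 4 values shown sit. The compounds shown leave open whether any substituent on this amine nitrogen gives a measurable half-maximal dose.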